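Series notes: oxiranyl in place of bromoethyl at the carbonyl

A few compounds are considered here, and "the series" means these few. Any claim that something is new, unique, unknown or untested is made for them only; others in the source may bear on it.

Of the compounds shown here, two have been measured in an in vitro assay on BL21-DE3 cells for displacement of a labelled ligand from thyroid hormone receptor beta (Homo sapiens), read by fluorescence polarization; on this read-out lower numbers stand for stronger inhibition and higher numbers for weaker inhibition. Compound 1 `C#CC(=O)Nc1ccc(CCCCCC)cc1` gives 35100 nM, and compound 2 `CCCCCCc1ccc(C(=O)CCBr)cc1` gives 3000 nM. Among the measured compounds shown here, the single measured step, a 12-fold lower number from compound 1 to compound 2 (1.07 log units; beyond the scatter), is the only comparison at hand. For the measured compounds named here, compound 2 thus stands with the lower of the two numbers, compound 1 being its only neighbour and well beyond the scatter.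

Compound 3 `CCCCCCc1ccc(C(=O)C2CO2)cc1` differs from compound 2 by oxiran-2-yl in place of 2-bromoethyl on a carbonyl carbon. Going by the values given here, no measured step touches this position: the step from compound 1 to compound 2 exchanged the whole group on the aromatic carbon, including the carbonyl itself, whereas the present change keeps the carbonyl and swaps only the group on its far side. Among the compounds with values here, that step therefore does not carry over, and the series gives no direct precedent for the exchange. With nothing to point either way, the expectation in this assay is a step no larger than the usual scatter, estimated as no change at the digits printed from compound 2 to compound 3 (within the scatter). The estimate for compound 3 in this assay is accordingly 3000 nM, with an expected range of 900 nM to 10000 nM.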

Compound 3, half-maximal inhibitory concentration: 19100 nM
Estimate against measurement, compound 3: 6.4-fold (0.80 log units) below; measured number above the stated range.
By their numbers in this assay, from the lowest: compound 2; then compounds 3 and 1 (each within the scatter of the next).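

In this assay the group on the far side of the carbonyl proves to matter: with the carbonyl and the rest of the core held constant, oxiran-2-yl in place of 2-bromoethyl gives a 6.4-fold higher number from compound 2 to compound 3 (0.80 log units; beyond the scatter) and so marks this position as sensitive to the exchange. Compound 3 also comes close to compound 1, with a 1.8-fold lower number from compound 1 to compound 3 (0.26 log units; within the scatter) on the exchange of the whole group on the aromatic carbon, so the carbonyl on the aromatic carbon does not by itself carry the low number of compound 2. Nothing at hand accounts for the size of the step at this position.

The compounds shown leave open whether the difference tracks the bromine or the three-membered ring, since the exchange changes both at once; 2-chloroethyl or plain ethyl on the same carbonyl carbon would address the halogen, and an aziridin-2-yl ring would address the ring oxygen. Also open, as far as these compounds go, is whether a longer chain such as 3-bromopropyl on that carbonyl carbon keeps the number of compound 2 or moves it.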